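This account rests on a few compounds, and the source may have more. Where it says the series, first, only, none or still open, it means among the compounds named here.

Measured compounds:
compound 1, `COc1cc(F)ccc1-c1ccnc2[nH]c(C3CCN(CC(=O)N(C)C)CC3)cc12`; in an ADME assay on microsomes from liver (Homo sapiens) for metabolic stability (on this read-out higher numbers stand for fast clearance and lower numbers for slow clearance), compound 1 gives 14 uL/min.
compound 2, `CC(C)n1cc(-c2ccnc3[nH]c(C4CCN(CC(=O)N(C)C)CC4)cc23)ccc1=O`; in this assay compound 2 gives < 3 uL/min, which is a limit of the assay and not a number.

Compound 2 stands at the low end of the two values shown, and only as a limit (the limit of < 3 uL/min in this assay, at which 1 of the 2 values shown sits). For the measured compounds named here, the single measured step, an at least 4.6-fold lower number from compound 1 to compound 2 (0.66 log units; beyond the scatter), concerns the exchange of the aryl group on the aromatic carbon and says nothing about the substituent on the aromatic nitrogen. Compound 3, `CCn1cc(-c2ccnc3[nH]c(C4CCN(CC(=O)N(C)C)CC4)cc23)ccc1=O`, differs from compound 2 by hydrogen in place of methyl on a saturated chain carbon bound to an aromatic nitrogen and a saturated chain carbon. Going by the values given here, no measured step touches this position; the one step available bears on the question only by fixing where compound 2 sits, at the limit. With a change of this size, removal of a single carbon from the group on the aromatic nitrogen, no step beyond the scatter is expected in this assay, in either direction. Compound 3 is therefore expected to give 2.5 uL/min in this assay, with a range from 1 uL/min to 6 uL/min. The expected step is a step that the limit leaves unreadable from compound 2 to compound 3, and a result reported only as a limit is considered likely.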

Compound 3, intrinsic clearance in a liver preparation (reported as CLH), per the amount of preparation that the assay uses: < 3 uL/min
Compound 3 ended at the assay's limit; the forecaster's own chance of this, stated with the estimate: 60%; the middle value lies beyond the limit too.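

In this assay compound 3 gives < 3 uL/min, which is a limit of the assay and not a number. The isopropyl group on the aromatic nitrogen is thus not needed for the read-out to reach this limit, since the exchange of the aryl group with ethyl in its place still gives an at least 4.6-fold lower number from compound 1 to compound 3 (0.66 log units; beyond the scatter). The change from isopropyl to ethyl leaves the read-out at the same limit, so the step between the two compounds that carry these groups cannot be read, and any difference between them stays hidden: the limit of < 3 uL/min in this assay, at which 2 of the 3 values shown sit.

On these data alone, how far compound 2 and compound 3 lie past the limit stays open, and with it any order between them. Also open, as far as these compounds go, is whether another group on the aromatic nitrogen, such as a longer chain, a cyclopropyl ring or an amine, or plain hydrogen there, would bring the read-out in this assay back to a number, which would make this position readable.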